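Swapping a methoxy for hydrogen on compound 1

The source may report more compounds than this note shows. Statements on the series, on what has been measured and on what is new or still open speak of the compounds shown alone.

In a functional assay on U-87MG ATCC cells for antiproliferative activity against U-87 MG (Homo sapiens), read by MTT assay, with a stated time of 48 h (on this read-out higher numbers stand for weaker inhibition and lower numbers for stronger inhibition), three compounds have been measured so far:

- compound 1 `COc1ccc(-c2nc(C)c(C(=O)CSc3nc(-c4cccc(OC)c4)c(C#N)c(=O)[nH]3)s2)cc1` gives 15300 nM
- compound 2 `COc1cccc(-c2nc(SCC(=O)c3sc(-c4ccccc4)nc3C)[nH]c(=O)c2C#N)c1` gives 59700 nM
- compound 3 `COc1ccc(-c2nc(C)c(C(=O)CSc3nc(N)c(C#N)c(-c4ccc(OC)cc4)n3)s2)cc1` gives 1560 nM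

Compound 1 at 15300 nM stands second highest of the three, with compound 2 above it and compound 3 below it, both beyond the scatter.

The next compound to be tested is compound 4 `COc1ccc(-c2nc(C)c(C(=O)CSc3nc(-c4ccccc4)c(C#N)c(=O)[nH]3)s2)cc1` which has not yet been measured. Its difference from compound 1 is hydrogen in place of methoxy on an aromatic carbon and amounts to hydrogen in place of methoxy on an aromatic carbon, turning 3-methoxyphenyl into phenyl.

Among the compounds with values here, only one measured step bears on this change. Within the data shown here, the same swap made at the other methoxy of compound 1 gave a 3.9-fold higher number from compound 1 to compound 2 (0.59 log units; beyond the scatter) and this modest loss is the sole guide to direction. Among the measured compounds shown here, compound 3 differs from compound 1 in more than one place and offers no comparable step. A single step made elsewhere in the molecule is thin support, so the expected size is set somewhat below it. The step expected in this assay is a 2.1-fold higher number from compound 1 to compound 4 (0.32 log units; beyond the scatter) towards weaker inhibition. Compound 4 is expected at 32000 nM within an estimated range of 10000 nM to 85000 nM until a measurement settles it.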

Compound 4, half-maximal inhibitory concentration: 57300 nM
Compound 4: the middle estimate sits 1.8-fold (0.25 log units) below what was measured, within the range that was stated.
By their numbers in this assay, from the lowest: compound 3; then compound 1; then compounds 4 and 2 (each within the scatter of the next).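

The methoxy of the 3-methoxyphenyl group in compound 1 proves to count in its own right in this assay, since replacing it with hydrogen gives a 3.7-fold higher number from compound 1 to compound 4 (0.57 log units; beyond the scatter). This step is close in size to the one seen at the other methoxy, a 3.9-fold higher number from compound 1 to compound 2 (0.59 log units; beyond the scatter), so the loss seen earlier is not confined to one end of the molecule: in this pair of changes, each methoxy of compound 1 goes with stronger inhibition than hydrogen in its place. The measurements at hand offer nothing that accounts for either loss.

Going by these compounds, what remains open is whether the methoxy itself is needed on the 3-methoxyphenyl ring or whether another group, such as a hydroxyl, a fluorine atom, an ethoxy chain or an amine, would keep the value of compound 1 at that place. It is also unknown whether the same swap would cost as much on the core of compound 3, which carries an amine and stands well apart from the others at 1560 nM.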